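The source may report more compounds than this note shows. Statements on the series, on what has been measured and on what is new or still open speak of the compounds shown alone.

In a functional assay for inhibition, with Homo sapiens as the target (a lower number here means a stronger inhibitor, a higher number a weaker inhibitor), compound 1 `O=C(O)CCCCCCCCn1cc(-c2ccccc2)cn1` gives > 105000 nM, which is a limit. Compound 2 `O=C(O)CCCCCCn1cc(-c2ccccc2)c(-c2ccccc2)n1` gives > 92000 nM, also a limit. Compound 3 `O=C(O)CCCCCCCn1cc(-c2ccccc2)c(-c2ccccc2)n1` gives > 85000 nM, again a limit, so compound 3 has no numeric value to start from. The change to compound 4 `O=C(O)CCCCCCCCn1cc(-c2ccccc2)c(-c2ccccc2)n1` is carboxymethyl in place of carboxy on a saturated chain carbon, seven bonds along the chain from an aromatic nitrogen. Within the data shown here, the one measured step of this kind is a step that the two limits leave unreadable from compound 2 to compound 3, and it offers no readable size. No step beyond the scatter is therefore expected in this assay, and another limit is likely. The expected step is an at least 1.0-fold lower number from compound 3 to compound 4 (0.02 log units; that floor lies within the scatter). For compound 4 the estimated value is 80000 nM, with an expected range of 40000 nM to 110000 nM.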

Compound 4, half-maximal inhibitory concentration: 4500 nM
Beside the measured number, compound 4's estimate is 18-fold (1.25 log units) above it; measured number below the stated range.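

In this assay, carboxymethyl in place of carboxy, seven bonds along the chain from an aromatic nitrogen, gives an at least 18-fold lower number from compound 3 to compound 4 (1.27 log units; beyond the scatter), and 2-carboxyethyl in place of carboxy gives an at least 20-fold lower number from compound 2 to compound 4 (1.31 log units; beyond the scatter). At this chain length, phenyl in place of hydrogen on an aromatic carbon also matters, giving an at least 23-fold lower number from compound 1 to compound 4 (1.36 log units; beyond the scatter). Compound 3 carries a limit, so its step gives a floor and not a size: the limit of > 85000 nM in this assay, at which 1 of the 4 values shown sits.

The step between the two shorter diphenyl-bearing chains cannot be read. As far as these compounds go, whether a longer chain, or an amide in place of the terminal carboxylic acid, keeps a numeric value stays open.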